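Dropping the Methyl from the Aniline Ring

The source may report more compounds than this note shows. Statements on the series, on what has been measured and on what is new or still open speak of the compounds shown alone.

Compound 1 `COc1cccc(/C=C/C(=O)c2sc(Nc3cccc(C)c3)nc2C)c1` is one of two measured members of this small set. In a functional assay on NCI-H460 cells (Homo sapiens) for cytotoxicity, read by MTT assay (a higher number here means a weaker inhibitor, a lower number a stronger inhibitor), compound 1 gives > 25000 nM, which is a limit of the assay and not a number. For the measured compounds named here, the other measured member, compound 2 `COc1cc(/C=C/C(=O)c2sc(Nc3ccc(Cl)cc3)nc2C)cc(OC)c1OC`, gives 22000 nM in this assay; compounds 1 and 2 differ in more than one place, so no single step connects them, and their two values both sit at the weak end. Where compound 1 stands is therefore known only as a limit (the limit of > 25000 nM in this assay, at which 1 of the 2 values shown sits).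

Compound 3 `COc1cccc(/C=C/C(=O)c2sc(Nc3ccccc3)nc2C)c1` is the unmeasured member. It differs from compound 1 by hydrogen in place of methyl on an aromatic carbon, 3-methylphenyl becoming phenyl. Going by the values given here, no measured pair in this set shows the effect of that change. A single methyl is a small alteration, and with compound 1 already at a limit, no movement beyond the usual scatter is expected in this assay in either direction. Compound 3 is accordingly expected to give about 30000 nM, within a range of 12000 nM to 80000 nM. The estimated step is then a step that the limit leaves unreadable from compound 1 to compound 3.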

Compound 3, half-maximal inhibitory concentration: > 25000 nM
Compound 3 ended at the assay's limit; the forecaster's own chance of this, stated with the estimate: 60%; the middle value does not contradict the limit.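

No step can be read from compound 1 to compound 3, since both compounds stand at a limit of the assay and not at a number: the limit of > 25000 nM in this assay, at which 2 of the 3 values shown sit.

The compounds shown leave open whether hydrogen in place of methyl on the aromatic carbon changes the result in this assay at all, and how far past the limit either compound lies.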